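Swapping methoxy for fluoro on a shared core

A few compounds are considered here, and "the series" means these few. Any claim that something is new, unique, unknown or untested is made for them only; others in the source may bear on it.

Of the compounds shown here, three built on one shared core have been tested in a functional assay on SW-620 cells (Homo sapiens) for inhibition, read by sulforhodamine B assay, with a stated time of 48 h; a higher number here means that more compound is tolerated, a lower number that less compound is tolerated. Compound 1 `COc1cc(CNc2nc3cc(N)cc(N)c3nc2-c2ccccc2)cc(OC)c1OC` gives only a limit of the assay, < 50200 nM. Compound 2 `COc1ccc(CNc2nc3cc(N)cc(N)c3nc2-c2ccccc2)cc1` gives 70800 nM. Compound 3 `COc1ccc(Sc2nc3cc(N)cc(N)c3nc2-c2ccccc2)cc1` also gives only a limit of the assay, < 100000 nM. Where compound 3 stands is therefore known only as a limit: its value sits at the limit of < 100000 nM in this assay, at which 1 of the 3 values shown sits. Among the three values one further entry is also a limit, at the limit of < 50200 nM in this assay, at which 1 of the 3 values shown sits. Within the data shown here, no step between two measured compounds that differ in a single place has been worked out in this set.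

Compound 4 `Nc1cc(N)c2nc(-c3ccccc3)c(Sc3ccc(F)cc3)nc2c1` differs from compound 3 in one place: fluoro in place of methoxy on an aromatic carbon. Among the measured compounds shown here, with compound 3 known only as a limit, and with no measured step for this change, the step from compound 3 to compound 4 is expected to stay within the usual scatter, a step that the limit leaves unreadable from compound 3 to compound 4, in no firm direction. Compound 4 is accordingly estimated at 70000 nM, with a range from 30000 nM to 150000 nM, and a real chance that this assay again reports only a limit.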

Compound 4, concentration lethal to 50% of the cells: < 100000 nM
Compound 4: only a limit was reported; the forecaster's own chance of this, stated with the estimate: 50%; the middle value does not contradict the limit.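

Compound 3 and compound 4 both stop at the same limit of the assay, so the step from one to the other cannot be read: the limit of < 100000 nM in this assay, at which 2 of the 4 values shown sit.

On these data alone, what fluoro in place of methoxy on an aromatic carbon does in this assay therefore stays open.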